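A few compounds are considered here, and "the series" means these few. Any claim that something is new, unique, unknown or untested is made for them only; others in the source may bear on it.

Measured compounds:
compound 1 `CC(C)(C)c1ccc(Oc2ccc3c(NCCCNCc4ccco4)ccnc3c2)cc1` — 14500 nM
compound 2 `COc1ccc(Oc2ccc3c(NCCCNCc4cc(F)ccc4OC)ccnc3c2)cc1` — 14500 nM

In a physicochemical assay for solubility, with a stated time of 18 h, at pH 7.4 (on this read-out lower numbers stand for lower solubility and higher numbers for higher solubility), compound 1 gives 14500 nM. Compound 2 gives 14500 nM in this assay, which is level with compound 1 at the digits shown and thus within the scatter; the two cannot be ranked against each other.

Compound 3 `COc1cccc(Oc2ccc3c(NCCCNCc4ccco4)ccnc3c2)c1` has not yet been measured in this assay. It differs from compound 1 in one place: 3-methoxyphenyl in place of 4-(tert-butyl)phenyl on an oxygen on an aromatic ring. For the measured compounds named here, no step between two measured compounds tracks this exact change, so the expectation rests on the values at hand. Going by the values given here, the only comparison available, between compound 1 and compound 2, shows no movement beyond the scatter, and nothing measured points to a large shift in either direction. For compound 3 the estimated step from compound 1 is a 1.2-fold higher number from compound 1 to compound 3 (0.09 log units; within the scatter), that is, at most a small rise that may not clear the scatter. Compound 3 is therefore expected to give about 18000 nM in this assay, within a range from 7000 nM to 45000 nM.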

Compound 3, solubility: 14500 nM
Estimate against measurement, compound 3: 1.2-fold (0.09 log units) above, and the stated range covers the measured number.
By their numbers in this assay, from the lowest: compounds 1, 2 and 3 (each within the scatter of the next).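

For the compounds shown here, the swap of 4-(tert-butyl)phenyl for 3-methoxyphenyl on the oxygen gives the first comparison here in which only one place differs, and in this assay it shows no change at the digits printed from compound 1 to compound 3 (within the scatter) as the step. The entering group has fewer heavy atoms than the one that leaves and brings one hydrogen-bond acceptor, yet this read-out does not separate the two compounds. Nothing measured here speaks to why the read-out behaves this way.

From the compounds shown here alone, only these two aromatic groups can be compared at this place on the core of compound 1, so it remains open whether a group carrying an amine or a carboxylic acid would give a number beyond the scatter. Going by these compounds, it is also open whether the same swap would give the same result with a different group at the far end of the side chain.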